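Pyrrolidine amide of compound 1: an expected value

A few compounds are considered here, and "the series" means these few. Any claim that something is new, unique, unknown or untested is made for them only; others in the source may bear on it.

Compound 1 `COc1ccc(C[C@@H](O)/C=C/C=C/C(=O)NCc2ccccc2)cc1OC` carries a benzylamino group on the carbonyl carbon of the shared core. In a functional assay on IMR-32 cells (Homo sapiens) for antiproliferative activity, read by sulforhodamine B assay, with a stated time of 48 h (on this read-out higher numbers stand for weaker inhibition and lower numbers for stronger inhibition), compound 1 gives 16600 nM, the highest of the three numbers, though within the usual scatter of the other two. Among the compounds with values here, compound 2 `COc1ccc(C[C@@H](O)/C=C/C=C/C(=O)N2CCN(c3ccccn3)CC2)cc1OC` gives 11100 nM and compound 3 `COc1ccc(C[C@@H](O)/C=C/C=C/C(=O)N2CCN(c3ncccn3)CC2)cc1OC` gives 10800 nM; the single measured step, a 1.0-fold lower number from compound 2 to compound 3 (0.01 log units; within the scatter), concerns the ring on the amine nitrogen and not the amide itself. Compound 4 `COc1ccc(C[C@@H](O)/C=C/C=C/C(=O)N2CCCC2)cc1OC` differs from compound 1 by pyrrolidin-1-yl in place of benzylamino on a carbonyl carbon. Within the data shown here, no measured step swaps the benzylamino group for a ring amine; the only guide is that compounds 1, 2 and 3, with three different groups on the carbonyl carbon, all lie within the scatter of one another. The step is therefore expected to be a 1.3-fold lower number from compound 1 to compound 4 (0.11 log units; within the scatter), nothing beyond the scatter. Compound 4 is estimated at 13000 nM, with a range from 5000 nM to 35000 nM.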

Compound 4, half-maximal inhibitory concentration: 12000 nM
The estimate for compound 4 lay 1.1-fold (0.03 log units) above the measured number; low and high end bracket the measured number.
By their numbers in this assay, from the lowest: compounds 3, 2, 4 and 1 (each within the scatter of the next).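

In this assay, within the data shown here, the step is a 1.4-fold lower number from compound 1 to compound 4 (0.14 log units; within the scatter) and it is the first measured step at this position, on the carbonyl carbon. The swap removes both the six-membered aromatic ring of carbon only and the hydrogen-bond donor of benzylamino, and the number stays within the scatter of compound 1. No measurement shown here speaks to what lies behind this result.

Still open, as far as these compounds go, is whether any group on this carbonyl carbon moves the number beyond the scatter. A morpholine ring, a carboxylic acid or a longer chain carrying an amine would test this.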